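Swapping a piperidine for an ethylpiperazine on compound 2

A few compounds are considered here, and "the series" means these few. Any claim that something is new, unique, unknown or untested is made for them only; others in the source may bear on it.

Values in a functional assay on HL-60 cells (Homo sapiens) for antiproliferative activity, read by MTT assay, with a stated time of 24 h; on this read-out higher numbers stand for weaker inhibition and lower numbers for stronger inhibition:
Compound 1 `CCCCc1oc2ccccc2c1C(=O)c1ccc(OCC(=O)N[C@H](C)c2ccccc2)cc1`: > 50000 nM, a limit of the assay, not a number
Compound 2 `CCCCc1oc2ccccc2c1C(=O)c1cc(I)c(OCCCN2CCCCC2)c(I)c1`: 11500 nM

For the measured compounds named here, compound 2 therefore holds the only true number so far, which leaves nothing measured to rank it against. Compound 3 `CCCCc1oc2ccccc2c1C(=O)c1cc(I)c(OCCCN2CCN(CC)CC2)c(I)c1` differs from compound 2 in one place: 4-ethylpiperazin-1-yl in place of piperidin-1-yl on a saturated chain carbon, three bonds along the chain from an oxygen on an aromatic ring. Going by the values given here, no measured pair of compounds shows this kind of swap, so the expectation is loose, and no change beyond the scatter is expected in this assay, in either direction. The estimated change is a 1.2-fold lower number from compound 2 to compound 3 (0.06 log units; within the scatter). For compound 3 the expected value is 10000 nM, with an estimated range from 3000 nM to 32000 nM.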

Compound 3, half-maximal inhibitory concentration: 28500 nM
Beside the measured number, compound 3's estimate is 2.9-fold (0.45 log units) below it; measured number inside the range.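

In this assay the group on a saturated chain carbon, three bonds along the chain from an oxygen on an aromatic ring, turns out to matter: the swap gives a 2.5-fold higher number from compound 2 to compound 3 (0.39 log units; beyond the scatter) and so weakens inhibition. For the compounds shown here, this is the first step that can be read here, and it rests on a single pair. Nothing shown explains the change.

Still open, going by these compounds, is whether the second ring nitrogen or the ethyl group carries the loss. An unsubstituted piperazin-1-yl or a morpholin-4-yl at the same place would help to separate the two.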